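The source may hold more compounds than are shown below. What is called first, only, known or untested is meant among the compounds shown, and "the series" means these compounds.

Measured compounds in a functional assay on SGC-7901 cells (Homo sapiens) for antiproliferative activity, read by MTT assay, with a stated time of 24 h (a higher number here means a weaker inhibitor, a lower number a stronger inhibitor), each reported only as a limit:

- compound 1 `Cc1cccc(NNC(=O)c2ccc(NS(=O)(=O)c3cnc(O)nc3O)cc2)c1` gives > 20000 nM
- compound 2 `O=C(NNc1ccc(F)cc1)c1cccc(NS(=O)(=O)c2cnc(O)nc2O)c1` gives > 20000 nM
- compound 3 `Cc1ccccc1NNC(=O)c1ccccc1NS(=O)(=O)c1cnc(O)nc1O` gives > 20000 nM

Compound 1 therefore stands at a limit of the assay and not at a number. In this assay compound 1 gives > 20000 nM as that limit. Among the compounds with values here, the other two measured compounds sit in the same place (the limit of > 20000 nM in this assay, at which 3 of the 3 values shown sit), so the series so far offers no numerical value to compare.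

Compound 4 (`O=C(NNC(=O)c1ccccc1Cl)c1ccc(NS(=O)(=O)c2cnc(O)nc2O)cc1`) carries (2-chlorophenyl)carbonyl in place of 3-methylphenyl on an amine nitrogen. Within the data shown here, no two measured compounds differ in one place, so no measured step gives a size for this change. Resting on compound 1 and its limit (> 20000 nM), the expected change in this assay is none beyond the scatter, with no direction favoured ( estimated a step that the limit leaves unreadable from compound 1 to compound 4). For compound 4 the estimated value is 25000 nM, with an expected range from 9000 nM to 60000 nM.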

Compound 4, half-maximal inhibitory concentration: 3240 nM
The estimate for compound 4 lay 7.7-fold (0.89 log units) above the measured number; measured number below the stated range.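

In this assay, putting (2-chlorophenyl)carbonyl in place of 3-methylphenyl on an amine nitrogen gives an at least 6.1-fold lower number from compound 1 to compound 4 (0.79 log units; beyond the scatter), so the read-out at this position does respond to a single change. Because compound 1 stands at a limit, this size is a lower bound and the full size of the step cannot be read. Compound 4 is the only compound shown with a number, while compound 1, compound 2 and compound 3 all rest at a limit: the limit of > 20000 nM in this assay, at which 3 of the 4 values shown sit.

The compounds shown do not separate the carbonyl from the chlorine, so which part of the entering group goes with the step stays open. Going by these compounds, how a plain benzoyl or an acetyl group on the same nitrogen would read also remains unknown.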